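Compound 3: 1-carboxyethyl on the amide-type nitrogen

The compounds below may be only part of what the source reports. "The series", "measured", "known", "first", "only" and "open" are said of these compounds alone.

In a functional assay on PC-3 cells (Homo sapiens) for antiproliferative activity, read by MTT assay, with a stated time of 24 h (a higher number here means a weaker inhibitor, a lower number a stronger inhibitor), compound 1 `CCn1c(C(=O)N[C@@H](C)CO)ccc1C(CC)(CC)c1ccc(OCS(=O)(=O)c2ccccc2)c(C)c1` gives 9520 nM and compound 2 `CCn1c(C(=O)N[C@H](CO)CCCO)ccc1C(CC)(CC)c1ccc(OCS(=O)(=O)c2ccccc2)c(C)c1` gives 6810 nM. These two values lie within the scatter of each other, so compound 2 stands level with compound 1 and neither ranks ahead. Compound 3 `CCn1c(C(=O)N[C@H](C)C(=O)O)ccc1C(CC)(CC)c1ccc(OCS(=O)(=O)c2ccccc2)c(C)c1` has not yet been measured. It differs from compound 2 as follows: a group of 5 heavy atoms (3 carbon, 2 oxygen; no ring) in place of a group of 7 heavy atoms (5 carbon, 2 oxygen; no ring), on an amide-type nitrogen. The entering group is 1-carboxyethyl, and the shared core is unchanged. Within the data shown here, the one measured step that bears on this is a 1.4-fold lower number from compound 1 to compound 2 (0.15 log units; within the scatter), where 2-hydroxyethyl stands in place of hydrogen on a saturated chain carbon of the same substituent. That step stays within the scatter. Among the measured compounds shown here, neither compound 1 nor compound 2 carries 1-carboxyethyl, however, so the data hold no direct precedent for the new group. As far as these compounds go, no step beyond the scatter is therefore expected in this assay, although the uncertainty is wide and a move in either direction remains open. The expected size is a 1.3-fold higher number from compound 2 to compound 3 (0.12 log units; within the scatter). For compound 3 the estimated value is 9000 nM, with an expected range of 3500 nM to 25000 nM.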

Compound 3, half-maximal inhibitory concentration: 20100 nM
Beside the measured number, compound 3's estimate is 2.2-fold (0.35 log units) below it, within the range that was stated.
By their numbers in this assay, from the lowest: compounds 2 and 1 (each within the scatter of the next); then compound 3.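

In this assay, the amide-type nitrogen now shows a change that moves the number beyond the scatter, unlike the 2-hydroxyethyl swap on the saturated chain carbon: a 3.0-fold higher number from compound 2 to compound 3 (0.47 log units; beyond the scatter), and a 2.1-fold higher number from compound 1 to compound 3 (0.32 log units; beyond the scatter). The second step is the tighter comparison, since 1-carboxyethyl replaces 1-(hydroxymethyl)ethyl, and it shows that a carboxylic acid in place of the hydroxymethyl end goes with a modest rise in the number, in the same direction as the step against the longer substituent of compound 2. No measurement at hand accounts for this rise.

As far as these compounds go, whether the rise belongs to the free carboxylic acid itself stays open, and a methyl ester or a primary amide in the same place on the amide-type nitrogen would test that against compound 3. Also open, from the compounds shown here alone, is whether an amine, or a longer chain ending in a carboxylic acid, on this nitrogen would stay level with compound 3 or return the number towards that of compound 2.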